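A few compounds are considered here, and "the series" means these few. Any claim that something is new, unique, unknown or untested is made for them only; others in the source may bear on it.

In a physicochemical assay for lipophilicity, measured as octanol-water partition (on this read-out lower numbers stand for lower lipophilicity and higher numbers for higher lipophilicity), the three measured compounds stand as follows:

compound 1 `CCO/N=C/Nc1cc(Cl)cc(Cl)c1` gives 3
compound 2 `CCO/N=C/Nc1cc(Cl)c(CC)c(Cl)c1` gives 4.8
compound 3 `CCO/N=C/Nc1cc(Cl)c(OC)c(Cl)c1` gives 3.7

Compound 2 holds the highest of the three numbers. The nearest of the other two is reached by the step of a number 1.10 log units lower from compound 2 to compound 3 (beyond the scatter), and the furthest by the reverse of the step of a number 1.80 log units higher from compound 1 to compound 2 (beyond the scatter); both gaps lie beyond the scatter.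

Compound 4 `CCO/N=C/Nc1cc(Cl)c(OCOC)c(Cl)c1` differs from compound 2 in a single place: methoxymethoxy in place of ethyl on an aromatic carbon. The step that bears most directly on this change is a number 1.10 log units lower from compound 2 to compound 3 (beyond the scatter). Methoxy, like methoxymethoxy, is attached through an oxygen, and that exchange was large. The step of a number 0.70 log units higher from compound 1 to compound 3 (beyond the scatter) shows that methoxy still sits above hydrogen, so the new group is not expected to fall as far as compound 1. A large downward step in this assay, beyond the scatter, is therefore expected from compound 2 to compound 4, roughly a number 1.20 log units lower from compound 2 to compound 4 (beyond the scatter).

Compound 4 is estimated at 3.6, within a range from 3.1 to 4.1.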

Compound 4, partition coefficient: 3.7
Compound 4: the middle estimate sits 0.10 log units below what was measured; measured number inside the range.
By their numbers in this assay, from the lowest: compound 1; then compounds 3 and 4 (each within the scatter of the next); then compound 2.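

In this assay, lengthening the group on this aromatic carbon from methoxy to methoxymethoxy gives no change at the digits printed from compound 3 to compound 4 (within the scatter), so the added methoxy on the chain carbon leaves no mark on this read-out, even though the group grows. The exchange of ethyl for methoxymethoxy gives a number 1.10 log units lower from compound 2 to compound 4 (beyond the scatter), and putting methoxymethoxy in place of hydrogen gives a number 0.70 log units higher from compound 1 to compound 4 (beyond the scatter), so on these numbers the two groups attached through oxygen cannot be told apart at this position. Nothing measured here gives a reason for this sameness.

Going by these compounds, it remains open whether a longer chain such as ethoxyethoxy, or a group carrying an amine or a carboxylic acid, would stay level with compound 3 and compound 4. On these data alone, it is also open whether methoxy and methoxymethoxy would match on a core without the two chloro groups.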